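This account rests on a few compounds, and the source may have more. Where it says the series, first, only, none or still open, it means among the compounds named here.

Measured compounds:
compound 1 `COc1ccc2[nH]c3c(c2c1)CCNC31CCN(Cc2cc(F)cc(Cl)c2)CC1` gives 2500 nM in an assay on FRT cells for positive allosteric modulation of Cystic fibrosis transmembrane conductance regulator variant N1303K (Homo sapiens), in the presence of a further agent that is not named here; on this read-out higher numbers stand for an effect only at larger amounts of compound and lower numbers for an effect already at smaller amounts;
compound 2 `COc1ccc2[nH]c3c(c2c1)CCNC31CCN(Cc2ccccc2Cl)CC1` gives 2200 nM in this assay;
compound 3 `COc1ccc2[nH]c3c(c2c1)CCNC31CCN(Cc2ccc(F)c(F)c2)CC1` gives 11000 nM in this assay.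

Among these three numbers compound 1 stands second highest. Compound 2 lies within the scatter of it, a 1.1-fold lower number from compound 1 to compound 2 (0.06 log units; within the scatter), whereas compound 3 lies beyond it, a 4.4-fold higher number from compound 1 to compound 3 (0.64 log units; beyond the scatter), and also a 5.0-fold higher number from compound 2 to compound 3 (0.70 log units; beyond the scatter).

Compound 4 `COc1ccc2[nH]c3c(c2c1)CCNC31CCN(Cc2ccccn2)CC1` has not yet been measured in this assay. Against compound 1 the change is pyridin-2-yl in place of 3-chloro-5-fluorophenyl on a saturated chain carbon bound to an amine nitrogen in a ring. The measured steps all exchange the aromatic group at this same place: one of them stayed within the scatter, the two others were modest in size. Among the compounds with values here, no measured step puts a pyridin-2-yl there. Compound 4 is therefore expected to give a number near that of compound 1, with the step of a 1.6-fold higher number from compound 1 to compound 4 (0.20 log units; within the scatter) estimated to stay inside the modest size seen so far; the estimate for compound 4 is 4000 nM, ranging from 1500 nM to 12000 nM.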

Compound 4, half-maximal effective concentration: 11500 nM
The estimate for compound 4 lay 2.9-fold (0.46 log units) below the measured number; the range from low to high includes it.
By their numbers in this assay, from the lowest: compounds 2 and 1 (each within the scatter of the next); then compounds 3 and 4 (each within the scatter of the next).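

In this assay, pyridin-2-yl, the only group shown with a hetero atom in its ring, groups with 3,4-difluorophenyl and not with the two chlorine-bearing phenyl groups: a 4.6-fold higher number from compound 1 to compound 4 (0.66 log units; beyond the scatter) and a 5.2-fold higher number from compound 2 to compound 4 (0.72 log units; beyond the scatter) lie beyond the scatter, whereas a 1.0-fold higher number from compound 3 to compound 4 (0.02 log units; within the scatter) stays within it. Across these compounds, the higher numbers therefore go with both chlorine-free groups, and no compound shown goes against this split. No evidence is available that accounts for the split. Still open, on these data alone, is whether the ring nitrogen or the lack of chlorine goes with the higher numbers, a question on which a plain phenyl or a chloropyridinyl group at this place would bear.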